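The source may report more compounds than this note shows. Statements on the series, on what has been measured and on what is new or still open speak of the compounds shown alone.

Working notes on the series.

Compound 1 `CCCSc1nc(N/N=C/c2ccccc2Cl)c2nnn(Cc3ccccc3)c2n1` is the reference point. For the measured compounds named here, in a functional assay on MCF7 cells (Homo sapiens) for antiproliferative activity, read by MTT assay, with a stated time of 72 h (a lower number here means a stronger inhibitor, a higher number a weaker inhibitor), compound 1 gives 13800 nM, the lowest of the two numbers measured so far; the nearest is compound 3 `CCCSc1nc(N/N=C(\C)c2ccccc2O)c2nnn(Cc3cccc(Cl)c3)c2n1`, which gives 39900 nM, a gap beyond the scatter. Compound 2 `CCCSc1nc(N/N=C(\C)c2ccccc2O)c2nnn(Cc3ccccc3Cl)c2n1` reports only a limit, > 64000 nM, as noted in the limit of > 64000 nM in this assay, at which 1 of the 3 values shown sits. Going by the values given here, the single measured step, an at least 1.6-fold lower number from compound 2 to compound 3 (0.20 log units; that floor lies within the scatter), concerns the chlorophenyl on the saturated chain carbon bound to an aromatic nitrogen and not the halogen on the aryl hydrazone.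

Compound 4 `CCCSc1nc(N/N=C/c2ccccc2F)c2nnn(Cc3ccccc3)c2n1` differs from compound 1 by fluoro in place of chloro on an aromatic carbon; cut one bond further out, the difference reads 2-chlorophenyl to 2-fluorophenyl. Among the compounds with values here, no measured step touches this part of the structure, so nothing in the data supports a shift in either direction. The step of a 1.1-fold higher number from compound 1 to compound 4 (0.04 log units; within the scatter) is therefore expected to stay within the scatter. For compound 4 the expected value is 15000 nM, with a range from 6000 nM to 40000 nM.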

Compound 4, half-maximal inhibitory concentration: > 64000 nM
Compound 4 was reported as a limit (the forecaster's own chance of this, stated with the estimate: 10%); middle value at least 4.2-fold (0.63 log units) away from the limit.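

For the compounds shown here, the change from 2-chlorophenyl to 2-fluorophenyl gives an at least 4.6-fold higher number from compound 1 to compound 4 (0.66 log units; beyond the scatter), so this part of the structure, which no earlier step touched, is not neutral to a single halogen swap. In this assay compound 4 gives > 64000 nM, which is a limit of the assay and not a number, so the step has a floor but no upper end. The series now holds a second value of this kind: the limit of > 64000 nM in this assay, at which 2 of the 4 values shown sit.

With only chloro and fluoro shown on this aromatic carbon, it stays open whether a bromo, a methyl or a methoxy group there would track compound 1 or compound 4. Also open, as far as these compounds go, is whether the same swap would carry the same weight on the scaffold of compound 3.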